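The source may hold more compounds than are shown below. What is called first, only, known or untested is meant among the compounds shown, and "the series" means these compounds.

Measured compounds:
compound 1, `C[C@@H](NC(=O)Nc1cccc(C(F)(F)F)c1)c1ccccc1`: 70%
compound 2, `C[C@H](NC(=O)Nc1cccc(C(F)(F)F)c1)c1ccccc1`: 92%
compound 3, `C[C@@H](NC(=O)Nc1cc(C(F)(F)F)cc(C(F)(F)F)c1)c1ccccc1`: 53%

In an ADME assay on the whole organism with Oryza sativa as the target, tested at 10 uM (a lower number here means a stronger effect, a higher number a weaker effect of the compound at the concentration tested), compound 3 has the lowest of the three numbers: compound 1 lies a number 17 percentage points lower from compound 1 to compound 3 (beyond the scatter) away, and compound 2 further still. The question is what happens when compound 3 is turned into compound 4, `C[C@H](NC(=O)Nc1cc(C(F)(F)F)cc(C(F)(F)F)c1)c1ccccc1`. The change is the two compounds have the same atoms and bonds and differ only in configuration as drawn: 1 of 1 stereo elements differ; a stereocentre at a saturated chain carbon is drawn R in compound 3 and S in compound 4. One measured step speaks directly to it: a number 22 percentage points higher from compound 1 to compound 2 (beyond the scatter), a step that rests on (the fact that compounds 1 and 2 differ only in the configuration as drawn). The other measured step, a number 17 percentage points lower from compound 1 to compound 3 (beyond the scatter), concerns the entry of trifluoromethyl and does not bear on the configuration. Among the measured compounds shown here, with only one earlier example of this kind of change, the expectation is a step in the same direction and of similar size, beyond the scatter. For compound 4 the expected value in this assay is 75%, estimated to fall between 58% and 92%. That corresponds to an expected step of a number 22 percentage points higher from compound 3 to compound 4 (beyond the scatter).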

Compound 4, a percentage reported as activity, at one concentration (the size of the read-out at that concentration, not a potency): 86%
The estimate for compound 4 lay 11 percentage points below the measured number; the range from low to high includes it.
By their numbers in this assay, from the lowest: compound 3; then compound 1; then compounds 4 and 2 (each within the scatter of the next).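

With a second pair, the change at the stereocentre on the saturated chain carbon is no longer a single case in this assay: a number 33 percentage points higher from compound 3 to compound 4 (beyond the scatter) runs the same way as a number 22 percentage points higher from compound 1 to compound 2 (beyond the scatter), so in both pairs the compound drawn S has the higher number. The pair rests on configuration alone: the fact that compounds 3 and 4 differ only in the configuration as drawn. The added trifluoromethyl gives a step beyond the scatter only with the R configuration, while a number 6 percentage points lower from compound 2 to compound 4 (within the scatter) stays within it, yet the two steps cannot be told apart: the same change on two cores in this assay, a number 17 percentage points lower (beyond the scatter) from compound 1 to compound 3 and a number 6 percentage points lower (within the scatter) from compound 2 to compound 4, 11 percentage points apart, within the scatter of two such steps.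

Going by these compounds, it remains open whether this preference for R holds when an amine or a carboxylic acid replaces trifluoromethyl on the aromatic ring, or when a longer chain replaces the methyl at the stereocentre. The compounds shown also leave open how these differences would look across a range of concentrations.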